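A few compounds are considered here, and "the series" means these few. Any claim that something is new, unique, unknown or untested is made for them only; others in the source may bear on it.

Measured in a toxicity assay on NIH3T3 cells (Mus musculus) for cytotoxicity, read by resazurin assay; a lower number here means that less compound is needed, a higher number that more compound is needed for the effect:
- Compound 1 `Clc1ccc(NCc2cncn2Cc2ccc(-c3ccccc3)cc2)cc1-c1ccccc1`: > 1000 nM, a limit
- Compound 2 `c1ccc(-c2ccc(Cn3cncc3CNc3ccc(-c4nc5ccccc5s4)c(-c4ccccc4)c3)cc2)cc1`: > 1000 nM, a limit
- Compound 3 `CCC(=O)c1ccc(NCc2cncn2Cc2ccc(-c3ccccc3)cc2)cc1-c1ccccc1`: > 10000 nM, a limit

None of the three compounds has a true number. Compound 3 stands only at a limit: the limit of > 10000 nM in this assay, at which 1 of the 3 values shown sits. Compounds 1 and 2 share the other limit: the limit of > 1000 nM in this assay, at which 2 of the 3 values shown sit.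

The next compound is compound 4 `CC(C)OC(=O)c1ccc(NCc2cncn2Cc2ccc(-c3ccccc3)cc2)cc1-c1ccccc1`, where isopropoxy takes the place of ethyl on a carbonyl carbon, so that propanoyl becomes isopropoxycarbonyl: isopropoxy in place of ethyl on a carbonyl carbon.

Among the compounds with values here, two measured steps bear on this change: a step that the two limits leave unreadable from compound 1 to compound 3, and a step that the two limits leave unreadable from compound 2 to compound 3. Within the data shown here, neither has a readable size, and no measured step alters the group on the carbonyl carbon. There is therefore no measured basis for a direction, and no step beyond the scatter is expected in this assay.

This expectation rests on compound 3 and its limit, > 10000 nM. The expected change is a number no higher from compound 3 to compound 4 (the limit leaves the size open). Compound 4 is also expected to be reported as a limit rather than a number. For compound 4 the estimated value is 10000 nM, with an expected range from 3000 nM to 30000 nM.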

Compound 4, half-maximal effective concentration: > 10000 nM
Compound 4: only a limit was reported; the forecaster's own chance of this, stated with the estimate: 85%; the middle value lies on the limit itself.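

In this assay compound 4 is reported only as a limit, > 10000 nM. No new step can be read from compound 4 to compound 1, compound 2 or compound 3: all four compounds carry limits, not numbers. The compounds shown leave open whether any of these groups on the shared core changes the concentration needed for cytotoxicity, and by how much.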